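This account rests on a few compounds, and the source may have more. Where it says the series, first, only, none or still open, it means among the compounds named here.

Measured so far in an ADME assay on THP-1 cells (Homo sapiens) for cytotoxicity (on this read-out lower numbers stand for higher toxicity in this test and higher numbers for lower toxicity in this test), each value being a limit of the assay and not a number:

compound 1 `COC(=O)Nc1sc2c(c1C(=O)Nc1ccc(OC)cc1)CCCCC2`: > 50000 nM
compound 2 `O=C(Nc1ccc(Cl)cc1)c1c(NC(=O)C(F)(F)F)sc2c1CCCCC2`: > 50000 nM
compound 3 `COc1ccc(NC(=O)c2ccsc2NC(=O)C(F)(F)F)cc1`: > 50000 nM

Compound 2 has only a limit in this assay, > 50000 nM, so its true value is not known. The same holds across the series, which shows (the limit of > 50000 nM in this assay, at which 3 of the 3 values shown sit). Among the measured compounds shown here, no step between measured compounds is available, so the series gives no measured size of change for any substitution.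

Compound 4 `N#Cc1ccc(NC(=O)c2c(NC(=O)C(F)(F)F)sc3c2CCCCC3)cc1` has not yet been measured. It differs from compound 2 by a single substituent: cyano in place of chloro on an aromatic carbon. This is cyano in place of chloro on an aromatic carbon, para to a large group.

The expectation rests on compound 2 with its > 50000 nM and on the two other compounds, which give the same limit. The expected step of a number no higher from compound 2 to compound 4 (the limit leaves the size open) is none beyond the scatter, in either direction. The assay will most likely report only a limit again. For compound 4 the estimated value is 50000 nM, with an expected range from 25000 nM to 100000 nM.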

Compound 4, half-maximal cytotoxic concentration: 9110 nM
Estimate against measurement, compound 4: 5.5-fold (0.74 log units) above; the measured number lies below the stated range.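

In this assay, among the compounds shown here, compound 4 gives 9110 nM, the only number that is not a limit of the assay. Cyano in place of chloro on the aromatic carbon para to a large group produces an at least 5.4-fold lower number from compound 2 to compound 4 (0.73 log units; beyond the scatter), so this position is not silent in this test and the change moves the read-out towards higher toxicity. The size of the step is a minimum only, as its starting point is a limit of the assay and not a number: the limit of > 50000 nM in this assay, at which 3 of the 4 values shown sit.

Going by these compounds, whether this shift is particular to cyano stays open, as a group such as an amine or a carboxylic acid at the same place would test. Also open, on these data alone, is whether the same exchange has a similar effect on the core of compound 3.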